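The source may hold more compounds than are shown below. What is called first, only, known or untested is meant among the compounds shown, and "the series" means these compounds.

Compound 1 `COC(=O)C1=C(C)NC(=O)NC1c1cccs1` and compound 2 `CCCC(=O)C1=C(C)NC(=O)NC1c1cccs1` share one core and differ only in the group on a carbonyl carbon. In an assay on membranes from HeLa cells for displacement of a labelled ligand from adenosine receptor A3 (Homo sapiens), read by scintillation counting, with a stated time of 180 min, tested at 1 uM (on this read-out lower numbers stand for less inhibition and higher numbers for more inhibition at the one concentration tested (going by the name of the read-out)), compound 1 gives 3%, while compound 2 gives 2%. Going by the values given here, the one measured step, a number 1 percentage points lower from compound 1 to compound 2 (within the scatter), putting propyl in place of methoxy on a carbonyl carbon, lies within the scatter, so neither of the two numbers can be set above the other; compound 2 carries the lower figure, with compound 1 within the scatter of it. Compound 3 `CCNC(=O)C1=C(C)NC(=O)NC1c1cccs1` follows from compound 2 by the change (ethylamino in place of propyl on a carbonyl carbon). Among the compounds with values here, the single step at this carbonyl carbon was small, and both measured values sit near the floor of the scale, so the expectation for compound 3 in this assay is a step of a number 2 percentage points higher from compound 2 to compound 3 (within the scatter), not beyond the scatter. Compound 3 is therefore estimated at 4%, within a range from 0% to 15%.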

Compound 3, a percentage reported as inhibition, at one concentration (the size of the read-out at that concentration, not a potency): 4%
Beside the measured number, compound 3's estimate shows no gap at the digits printed; measured number inside the range.
By their numbers in this assay, from the lowest: compounds 2, 1 and 3 (each within the scatter of the next).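

In this assay, ethylamino in place of propyl on a carbonyl carbon gives a number 2 percentage points higher from compound 2 to compound 3 (within the scatter) and ethylamino in place of methoxy gives a number 1 percentage points higher from compound 1 to compound 3 (within the scatter), so a third kind of group at this place leaves the numbers within the scatter of one another. Even the hydrogen-bond donor that ethylamino brings, where propyl has none, does not produce a step beyond the scatter, and the three compounds cannot be ranked. No measurement shown here accounts for this result.

From the compounds shown here alone, whether a longer chain, a benzylamino group or a carboxylic acid on this carbonyl carbon would produce a step beyond the scatter remains open. So does the effect of a change elsewhere on the shared core, since all three compounds differ only at this one place.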